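Trimming isobutyl to isopropyl on a shared core

A few compounds are considered here, and "the series" means these few. Any claim that something is new, unique, unknown or untested is made for them only; others in the source may bear on it.

Values in a functional assay on K562 cells (Homo sapiens) for inhibition (on this read-out higher numbers stand for weaker inhibition and lower numbers for stronger inhibition), for the compounds measured so far:
Compound 1 `CCC(=O)OC1C(C(O)CO)OC2OC(C)(C)OC21` gives 2400000 nM
Compound 2 `CC(C)CC(=O)OC1C(C(O)CO)OC2OC(C)(C)OC21` gives 1000000 nM
Compound 3 `CC1(C)OC2OC(C(O)CO)C(OC(=O)CC(c3ccccc3)c3ccccc3)C2O1` gives 500000 nM

The three compounds share one core and differ in the group on the carbonyl carbon. Compound 2 stands at 1000000 nM and lies within the usual scatter of compound 3 at 500000 nM on these numbers. Compound 1 stands apart, and the measured step is a 2.4-fold lower number from compound 1 to compound 2 (0.38 log units; beyond the scatter) with nothing larger to compare it against.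

Compound 4 `CC(C)C(=O)OC1C(C(O)CO)OC2OC(C)(C)OC21` has not yet been measured. It differs from compound 2 by isopropyl in place of isobutyl on a carbonyl carbon and in no other place. For the measured compounds named here, only that one measured step bears on this change, and it is not the same change, since it put isopropyl in place of methyl on a saturated chain carbon bound to a carbonyl carbon. As a rough guide, trimming the chain of compound 2 may move the number back toward compound 1 at 2400000 nM without reaching it. The expected step is a 1.5-fold higher number from compound 2 to compound 4 (0.18 log units; within the scatter) and it is estimated to be small, toward a higher number. Compound 4 is estimated at 1500000 nM with an expected range from 700000 nM to 3000000 nM in this assay once it is tested.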

Compound 4, half-maximal inhibitory concentration: 2500000 nM
The estimate for compound 4 lay 1.7-fold (0.22 log units) below the measured number, and the stated range covers the measured number.
By their numbers in this assay, from the lowest: compounds 3 and 2 (each within the scatter of the next); then compounds 1 and 4 (each within the scatter of the next).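

Within this assay, the group on the carbonyl carbon proves sensitive to a very small edit: isopropyl in place of isobutyl gives a 2.5-fold higher number from compound 2 to compound 4 (0.40 log units; beyond the scatter), so removing one carbon from this group produces a step beyond the scatter. The other new comparison, a 1.0-fold higher number from compound 1 to compound 4 (0.02 log units; within the scatter), lies within the scatter, which means that the methyl separating these two compounds has no readable effect on this read-out, and compound 1 and compound 4 cannot be told apart here, while the isobutyl ester compound 2 stands apart from both. Nothing given here offers a measured explanation for why the isobutyl group differs from the two smaller groups in this way.

These few esters leave open whether the trend with isobutyl would continue along a longer chain, such as a straight hexyl chain, or whether it is specific to that one group. They also leave open how an amine or a carboxylic acid placed on the chain would read in this assay, since every group compared so far is a plain hydrocarbon.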